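Ester tail swap on a thiophene-bearing and a furan-bearing core

The compounds below may be only part of what the source reports. "The series", "measured", "known", "first", "only" and "open" are said of these compounds alone.

Measured so far:
- compound 1, `CC1=C(C(=O)OCC(C)C)C(c2ccsc2)NC(=S)N1`: 2%
- compound 2, `CC1=C(C(=O)OC(C)(C)C)C(c2ccsc2)NC(=S)N1`: 16%
- compound 3, `CC1=C(C(=O)OCC(C)C)C(c2ccoc2)NC(=O)N1C`: 16%

All three were tested in an assay on membranes from HeLa cells for displacement of a labelled ligand from adenosine receptor A3 (Homo sapiens), read by scintillation counting, with a stated time of 180 min, tested at 1 uM; on this read-out lower numbers stand for less inhibition and higher numbers for more inhibition at the one concentration tested (going by the name of the read-out). Compound 1 and compound 2 share one core and differ in a single place: tert-butyl in place of isobutyl on an oxygen next to a carbonyl group. This change gave a number 14 percentage points higher from compound 1 to compound 2 (beyond the scatter), a step that lies beyond the scatter of the method.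

Compound 3 rests on a different core. How the two cores differ is not broken down here. In this assay compound 3 gives 16%, level with compound 2 at the digits shown, and higher than compound 1 by a step that lies beyond the scatter.

The unmeasured compound 4, `CC1=C(C(=O)OC(C)(C)C)C(c2ccoc2)NC(=O)N1C`, is related to compound 3 by the same change that turns compound 1 into compound 2: tert-butyl in place of isobutyl on an oxygen next to a carbonyl group. The surroundings of the place are described in the same words in both pairs, so the change is the same, although it is now made on the other core.

Among the measured compounds shown here, on the only precedent, the step from compound 1 to compound 2, the expectation is that compound 4 will move upward from compound 3 by about a number 11 percentage points higher from compound 3 to compound 4 (beyond the scatter), a step estimated to be of similar size to the earlier one because that earlier step read a number 14 percentage points higher from compound 1 to compound 2 (beyond the scatter). One case on a different core is a thin basis, so the range is wide. The estimate for compound 4 in this assay is 27%, expected to fall between 10% and 45%.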

Compound 4, a percentage reported as inhibition, at one concentration (the size of the read-out at that concentration, not a potency): 12%
Compound 4: the middle estimate sits 15 percentage points above what was measured; measured number inside the range.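

In this assay, putting tert-butyl in place of isobutyl on an oxygen next to a carbonyl group does not repeat its earlier result on the core of compound 3, where the new reading is a number 4 percentage points lower from compound 3 to compound 4 (within the scatter). The change therefore cannot be carried from the core of compound 1 to the core of compound 3 with its effect assumed intact, as the two steps differ by more than the method's scatter: the same change on two cores in this assay, a number 14 percentage points higher (beyond the scatter) from compound 1 to compound 2 and a number 4 percentage points lower (within the scatter) from compound 3 to compound 4, 18 percentage points apart, beyond the scatter of two such steps. This does not show which feature of the two cores separates the steps, nor does it give a rule for other cores, since each step rests on a single pair of compounds tested at one concentration.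

The compounds shown hold only isobutyl and tert-butyl on that oxygen, so it remains open whether a longer chain or a benzyl group there would give different readings on either core. From the compounds shown here alone, it also remains open whether the contrast between the two steps would hold at other concentrations, or on a core that differs from the core of compound 1 in only one place.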